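This account rests on a few compounds, and the source may have more. Where it says the series, first, only, none or still open, it means among the compounds named here.

Of the compounds shown here, three have been tested in a functional assay on HT-29 cells (Homo sapiens) for antiproliferative activity, read by sulforhodamine B assay, with a stated time of 48 h; on this read-out lower numbers stand for stronger inhibition of growth and higher numbers for weaker inhibition of growth. Compound 1 `NS(=O)(=O)NCC1CCN(c2cc(-c3ccc(Cl)cc3)ncn2)CC1` gives 37700 nM in this assay. Compound 2 `NS(=O)(=O)NCC1CCN(c2cc(-c3ccc(C(F)(F)F)cc3)ncn2)CC1` differs from compound 1 by trifluoromethyl in place of chloro on an aromatic carbon, and in this assay compound 2 gives 29100 nM, a step of a 1.3-fold lower number from compound 1 to compound 2 (0.11 log units; within the scatter). Compound 3 `NS(=O)(=O)NCCC1CCN(c2cc(-c3ccc(Cl)cc3)ncn2)CC1` differs from compound 1 by (sulfamoylamino)methyl in place of sulfamoylamino on a saturated chain carbon bound to a saturated ring carbon, and in this assay compound 3 gives 30500 nM, a step of a 1.2-fold lower number from compound 1 to compound 3 (0.09 log units; within the scatter). Compound 4 `NS(=O)(=O)NCCC1CCN(c2cc(-c3ccc(C(F)(F)F)cc3)ncn2)CC1` is not yet measured; it differs from compound 3 by trifluoromethyl in place of chloro on an aromatic carbon, the same change already seen between compound 1 and compound 2, at a place described in the same words. From compound 3 to compound 4 a step of a 1.3-fold lower number from compound 3 to compound 4 (0.10 log units; within the scatter) is expected in this assay, resting on the earlier step of a 1.3-fold lower number from compound 1 to compound 2 (0.11 log units; within the scatter), which was within the scatter. Compound 4 is therefore estimated at 24000 nM, most likely between 12000 nM and 48000 nM.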

Compound 4, concentration for 50% growth inhibition: 22600 nM
Beside the measured number, compound 4's estimate is 1.1-fold (0.03 log units) above it; the range from low to high includes it.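

In this assay, trifluoromethyl in place of chloro gives a 1.3-fold lower number from compound 3 to compound 4 (0.13 log units; within the scatter), and the two cores agree on this change: the same change on two cores in this assay, a 1.3-fold lower number (0.11 log units; within the scatter) from compound 1 to compound 2 and a 1.3-fold lower number (0.13 log units; within the scatter) from compound 3 to compound 4, 1.0-fold (0.02 log units) apart, within the scatter of two such steps. The other change, (sulfamoylamino)methyl in place of sulfamoylamino, gives a 1.3-fold lower number from compound 2 to compound 4 (0.11 log units; within the scatter), and here too the two cores agree: the same change on two cores in this assay, a 1.2-fold lower number (0.09 log units; within the scatter) from compound 1 to compound 3 and a 1.3-fold lower number (0.11 log units; within the scatter) from compound 2 to compound 4, 1.0-fold (0.02 log units) apart, within the scatter of two such steps. Among these compounds, every one of these steps lies within the scatter, so the agreement shows only that neither change gave a measurable shift on either core, and it does not show that a real effect carries from one core to another.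

Still open, going by these compounds, is whether a step beyond the scatter would come from a nitrile or a methoxy group in place of chloro. The same question stands for a longer chain, or an amine in place of the sulfamoylamino group.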